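The source may report more compounds than this note shows. Statements on the series, on what has been measured and on what is new or still open speak of the compounds shown alone.

Within the data shown here, in an ADME assay for permeability, using PAMPA, at pH 7.4 (a higher number here means that the compound crosses the layer faster, a lower number that the compound crosses the layer more slowly), compound 1 `Cc1cc(NC(=O)Nc2ccc(C(C)(C)C)cc2)c2ccccc2n1` gives 142 10^-6 cm/s, the second highest of the three numbers measured so far. Compound 2 `Cc1cc(NC(=O)Nc2ccccc2N)c2ccccc2n1` gives 300 10^-6 cm/s, a higher number, while compound 3 `Cc1cc(NC(=O)Nc2ccc3[nH]cnc3c2)c2ccccc2n1` lies far lower at 2 10^-6 cm/s. These three compounds differ in more than one place, so no single change can be read from them. Compound 4 `COC(=O)c1ccc(NC(=O)Nc2cc(C)nc3ccccc23)cc1` departs from compound 1 in one place: methoxycarbonyl in place of tert-butyl on an aromatic carbon. In this assay, among the measured compounds shown here, a small decrease is expected, probably within the scatter, though the data offer no direct precedent. The estimated step is a 1.6-fold lower number from compound 1 to compound 4 (0.20 log units; within the scatter). For compound 4 the expected value is 90 10^-6 cm/s, with an estimated range from 30 10^-6 cm/s to 270 10^-6 cm/s.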

Compound 4, apparent permeability: 448 10^-6 cm/s
Beside the measured number, compound 4's estimate is 5.0-fold (0.70 log units) below it; the whole stated range lies below it.
By their numbers in this assay, from the lowest: compound 3; then compound 1; then compounds 2 and 4 (each within the scatter of the next).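

Methoxycarbonyl in place of tert-butyl on an aromatic carbon gives a 3.2-fold higher number from compound 1 to compound 4 (0.50 log units; beyond the scatter) in this assay and is the first single change that can be read in this series. It shows that at this place, para to a large group, hydrogen-bond acceptors can enter with the ester and the number still rises. Nothing measured here accounts for this step. The compounds shown leave open whether a carboxylic acid, an amine or a nitrile at this place would move the number the same way, and whether the step holds on a different core.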